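A Methoxy Added to the Isopropyl Group

A few compounds are considered here, and "the series" means these few. Any claim that something is new, unique, unknown or untested is made for them only; others in the source may bear on it.

Three compounds share a urea-linked design, and their values in a functional assay on OCI-Ly3 cells (Homo sapiens) for antiproliferative activity (a lower number here means that less compound is needed, a higher number that more compound is needed for the effect), span a wide range. Compound 1 `O=C(Nc1cnc(-n2nccn2)c(Cl)c1)Nc1cncc2ccccc12` reached only a limit of the assay, > 20000 nM. Compound 2 `Cc1c(NC(=O)Nc2cnc(-n3nccn3)c(Cl)c2)cnc2ccc(Br)cc12` gave a measured number of 12900 nM. Among the measured compounds shown here, compound 3 `CC(C)c1c(NC(=O)Nc2cnc(-n3nccn3)c(Cl)c2)cnc2ccccc12` gave 2420 nM, the lowest number so far, and its gap to compound 2 lies beyond the scatter.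

Compound 4 `COC(C)(C)c1c(NC(=O)Nc2cnc(-n3nccn3)c(Cl)c2)cnc2ccccc12` changes compound 3 in one place: methoxy in place of hydrogen on a saturated chain carbon bound to an aromatic carbon and two saturated chain carbons. Methoxy replaces hydrogen on a saturated chain carbon bound to an aromatic carbon and two saturated chain carbons, so isopropyl becomes 1-methoxy-1-methylethyl.

For the measured compounds named here, no measured pair shows this change, so the expectation starts from compound 3 at 2420 nM and remains uncertain. A modest move towards a lower number in this assay is expected, slightly beyond the scatter. The expected change is a 2.4-fold lower number from compound 3 to compound 4 (0.38 log units; beyond the scatter). For compound 4, the estimated value is 1000 nM, with an expected range from 200 nM to 6000 nM.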

Compound 4, half-maximal effective concentration: 4430 nM
The estimate for compound 4 lay 4.4-fold (0.65 log units) below the measured number, and the stated range covers the measured number.
By their numbers in this assay, from the lowest: compounds 3 and 4 (each within the scatter of the next); then compound 2. At a limit, above all of these: compound 1.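

In this assay, the step reads a 1.8-fold higher number from compound 3 to compound 4 (0.26 log units; within the scatter), so the numbers for the two compounds cannot be told apart. The earlier compounds shown here did not isolate this position, whereas this pair changes only the saturated chain carbon bound to an aromatic carbon and two saturated chain carbons, and isopropyl can become 1-methoxy-1-methylethyl there without a difference that stands clear of the usual scatter. Nothing measured here accounts for this result.

The compounds shown leave open whether another group on this same carbon, such as a hydroxyl, an amine or a carboxylic acid, would give a number clearly apart from that of compound 3. They also leave open whether a longer ether chain in place of methoxy would stay as close to compound 3 as compound 4 does.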